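Trifluoromethoxy added to the dimethoxy analogue of compound 2

This account rests on a few compounds, and the source may have more. Where it says the series, first, only, none or still open, it means among the compounds named here.

Compound 1 `COc1ccc2c(=O)cc(/C=C/c3ccc(OC(F)(F)F)cc3)oc2c1` gives, in a functional assay on SKHep cells (Homo sapiens) for antiproliferative activity, read by MTT assay, with a stated time of 12 h (on this read-out higher numbers stand for weaker inhibition and lower numbers for stronger inhibition), the assay limit > 40000 nM, a limit and not a number.
Compound 2 `COc1cc(OC)c2c(=O)cc(/C=C/c3ccccc3)oc2c1` gives in this assay 26000 nM.
Compound 3 `COc1ccc2c(=O)cc(/C=C/c3ccc(OC(F)(F)F)cc3)oc2c1OC` gives in this assay 12400 nM.

Among the two compounds that return a number in this assay, compound 2 stands highest, with compound 3 nearest and lower, beyond the scatter. For the measured compounds named here, the only single-point step among the measured compounds is an at least 3.2-fold lower number from compound 1 to compound 3 (0.50 log units; beyond the scatter), and it starts from a limit, so its full size is not known beyond (the limit of > 40000 nM in this assay, at which 1 of the 3 values shown sits).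

Compound 4 `COc1cc(OC)c2c(=O)cc(/C=C/c3ccc(OC(F)(F)F)cc3)oc2c1` differs from compound 2 by trifluoromethoxy in place of hydrogen on an aromatic carbon, on an aromatic carbon of a six-membered aromatic ring of carbon only, para to a large group. Going by the values given here, no measured pair isolates this change: compound 1 and compound 3 both already carry the trifluoromethoxy group, and compound 2 lacks it, so the effect of adding it is untested here. The measured step concerns methoxy on the shared core, not the styryl ring. On that basis no step beyond the scatter is expected in this assay, and the estimated change from compound 2 is a 1.3-fold lower number from compound 2 to compound 4 (0.11 log units; within the scatter).

Compound 4 is therefore expected to give about 20000 nM in this assay, within 6000 nM to 50000 nM.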

Compound 4, half-maximal inhibitory concentration: 12500 nM
Beside the measured number, compound 4's estimate is 1.6-fold (0.20 log units) above it; measured number inside the range.
By their numbers in this assay, from the lowest: compounds 3 and 4 (each within the scatter of the next); then compound 2. At a limit, above all of these: compound 1.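

In this assay, trifluoromethoxy in place of hydrogen on an aromatic carbon, para to a large group, now has a measured step of its own, a 2.1-fold lower number from compound 2 to compound 4 (0.32 log units; beyond the scatter), so this change on the six-membered aromatic ring of carbon only is no longer untested, and the step is modest. Methoxy in place of hydrogen on an aromatic carbon now has a second reading on another carbon of the shared core, an at least 3.2-fold lower number from compound 1 to compound 4 (0.50 log units; beyond the scatter), set against the earlier at least 3.2-fold lower number from compound 1 to compound 3 (0.50 log units; beyond the scatter), and as both start from a limit their full sizes cannot be read: the limit of > 40000 nM in this assay, at which 1 of the 4 values shown sits. The two methoxy placements cannot be told apart here, since compound 3 gives 12400 nM and compound 4 gives 12500 nM, which lie within the scatter of each other.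

For the compounds shown here, only one pair carries the trifluoromethoxy change, so whether it gives a similar step on other substitution patterns of the shared core remains open. Also open, from the compounds shown here alone, is how the number would respond at this same place to an amine, a carboxylic acid or a longer alkoxy chain.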